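Replacing the Methoxy Group of Compound 2 with a Nitrile

The source may report more compounds than this note shows. Statements on the series, on what has been measured and on what is new or still open speak of the compounds shown alone.

Of the compounds shown here, two have been measured in an assay on V79 cells for inhibition of cytochrome P450 11B2, mitochondrial (Homo sapiens), read by HTRF, with a stated time of 1 h; a lower number here means a stronger inhibitor, a higher number a weaker inhibitor. Compound 1 `Fc1ccc2nc(-c3cccnc3)n(C3CC3)c2c1` gives 4 nM. For the measured compounds named here, compound 2 `COc1ccc2nc(-c3cccnc3)n(C3CC3)c2c1` gives 24 nM, the highest of the two numbers so far; its nearest neighbour is compound 1, and the only measured step, a 6.0-fold higher number from compound 1 to compound 2 (0.78 log units; beyond the scatter), separates them. Compound 3 `N#Cc1ccc2nc(-c3cccnc3)n(C3CC3)c2c1` has not yet been measured in this assay. The change from compound 2 to compound 3 is cyano in place of methoxy on an aromatic carbon. Going by the values given here, the one measured step bears on it only indirectly: it shows that the methoxy group at this place gave a modest increase over fluoro in compound 1, so a further exchange at the same place can plausibly move the number by a comparable amount in either direction, or leave it within the scatter. Because compound 1 gives 4 nM and compound 2 gives 24 nM, compound 3 is expected to fall between them, with the step of a 2.4-fold lower number from compound 2 to compound 3 (0.38 log units; beyond the scatter). The estimate for compound 3 is therefore 10 nM, with a range from 3 nM to 40 nM.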

Compound 3, half-maximal inhibitory concentration: 1.2 nM
Beside the measured number, compound 3's estimate is 8.3-fold (0.92 log units) above it; measured number outside the range, below it.
By their numbers in this assay, from the lowest: compound 3; then compound 1; then compound 2.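

In this assay, for the compounds shown here, cyano in place of methoxy gives a 20-fold lower number from compound 2 to compound 3 (1.30 log units; beyond the scatter) and so marks a large step, whereas the only earlier exchange at this aromatic carbon, a 6.0-fold higher number from compound 1 to compound 2 (0.78 log units; beyond the scatter) and rated modest, showed a much smaller spread. Cyano in place of fluoro gives a 3.3-fold lower number from compound 1 to compound 3 (0.52 log units; beyond the scatter) and shows that the number of compound 1 was not the floor at this place, since compound 3 now has the lowest number of the three, with its steps to both others beyond the scatter. Methoxy and cyano have the same count of heavy atoms and of hydrogen-bond acceptors, and neither carries a net charge, so those counts do not separate them, and nothing measured here accounts for the difference.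

Whether the low number belongs to cyano alone remains open, as the compounds shown do not say how an amine, a carboxylic acid or a trifluoromethyl group would fare on the same aromatic carbon. From the compounds shown here alone, it is also open whether the order of cyano, fluoro and methoxy would hold if another part of the shared core were changed.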